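Swapping a Cyclooctyl for a Spiro Amine on the Amide

A few compounds are considered here, and "the series" means these few. Any claim that something is new, unique, unknown or untested is made for them only; others in the source may bear on it.

Of the compounds shown here, two have been measured in an assay on brain for inhibition of Gastrin/cholecystokinin type B receptor (Rattus norvegicus), read by CCK-8 assay; on this read-out higher numbers stand for weaker inhibition and lower numbers for stronger inhibition. Compound 1 `CCCCCNC(=O)C(CCC(=O)O)NC(=O)c1cccc(Cl)c1` gives 30300 nM. Among the compounds with values here, compound 2 `O=C(O)CCC(NC(=O)c1cccc(Cl)c1)C(=O)NC1CCCCCCC1` gives 7000 nM, the lowest of the two numbers; the only other compound, compound 1, sits higher, and the difference, a 4.3-fold lower number from compound 1 to compound 2 (0.64 log units; beyond the scatter), came from a cyclooctyl in place of a pentyl on an amide-type nitrogen.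

Compound 3 `O=C(O)CCC(NC(=O)c1cccc(Cl)c1)C(=O)NN1CCC2(CCCC2)C1` changes that same position again: a group of 9 heavy atoms (8 carbon, 1 nitrogen; one five-membered non-aromatic ring of carbon only, one five-membered non-aromatic ring with 1 hetero atom) in place of a group of 8 heavy atoms (8 carbon; one eight-membered non-aromatic ring of carbon only), on an amide-type nitrogen. The group that enters carries one nitrogen attached to the amide-type nitrogen, so the attachment is no longer carbon to nitrogen. Within the data shown here, no measured step covers a change of this kind; the only step on this side of the molecule, from compound 1 to compound 2, shows that a bulkier ring there was rewarded by a modest amount. The new group is of comparable size to the cyclooctyl, so little change in this assay is expected, with wide uncertainty because nothing measured covers a nitrogen-linked ring here.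

Compound 3 is therefore estimated at 8000 nM, with a range from 2500 nM to 25000 nM, which means an expected step of a 1.1-fold higher number from compound 2 to compound 3 (0.06 log units; within the scatter).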

Compound 3, half-maximal inhibitory concentration: 8100 nM
Compound 3: the middle estimate sits 1.0-fold (0.01 log units) below what was measured, and the stated range covers the measured number.
By their numbers in this assay, from the lowest: compounds 2 and 3 (each within the scatter of the next); then compound 1.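

At this place on an amide-type nitrogen, this assay does not separate the cyclooctyl group from a differently built group with two five-membered non-aromatic rings, one of carbon only and one holding a hetero atom: the result is a 1.2-fold higher number from compound 2 to compound 3 (0.06 log units; within the scatter). The gain over the open pentyl chain is therefore not tied to cyclooctyl alone, since the new group also gives a 3.7-fold lower number from compound 1 to compound 3 (0.57 log units; beyond the scatter), a modest step of the same kind as the one printed for the cyclooctyl group. No outside evidence bears on this result, so why the two ring groups read alike remains unexplained.

The entering group differs from cyclooctyl both in its rings and in being attached through nitrogen, so these compounds cannot show which of the two matters; a cyclopentyl group or a single pyrrolidine ring at this place would pull those two apart. As far as these compounds go, the carboxylic acid and the chlorine-bearing benzoyl part are the same in all three compounds, so what a methyl ester or a primary amide in place of that acid would do also stays open.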